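The source may hold more compounds than are shown below. What is called first, only, known or untested is meant among the compounds shown, and "the series" means these compounds.

Compound 1, `COc1ccc(C(=O)/C=C/c2ccc(Br)cc2)c2c1C=CC(C)(C)O2`, and compound 2, `CCN(CC)c1ccc(/C=C/C(=O)c2ccc(OC)c3c2OC(C)(C)C=C3)cc1`, share one core and differ in a single place on the outer ring. In a functional assay on SK-OV-3 cells (Homo sapiens) for antiproliferative activity, read by MTT assay, with a stated time of 24 h (a lower number here means a stronger inhibitor, a higher number a weaker inhibitor), compound 1 gives only a limit, > 10000 nM, with no number behind it. In this assay, among the measured compounds shown here, compound 2 gives 610 nM, the only number so far. The change from compound 1 to compound 2, diethylamino in place of bromo on an aromatic carbon, brings an at least 16-fold lower number from compound 1 to compound 2 (1.21 log units; beyond the scatter). Compound 3, `COc1ccc(C(=O)/C=C/c2ccc([N+](=O)[O-])cc2)c2c1C=CC(C)(C)O2`, is not yet measured; it arises from compound 2 by nitro in place of diethylamino on an aromatic carbon. The one measured step bears on this: the only number shown came from putting diethylamino in, and compound 3 now takes it out again. A large step toward a higher number is therefore expected in this assay, with a real chance that only a limit is returned. For compound 3 the estimate is 6000 nM, between 1500 nM and 25000 nM, that is a 9.8-fold higher number from compound 2 to compound 3 (0.99 log units; beyond the scatter).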

Compound 3, half-maximal inhibitory concentration: 3420 nM
The estimate for compound 3 lay 1.8-fold (0.24 log units) above the measured number; the measured number falls inside the stated range.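

Diethylamino is not the only group at this place that returns a number in this assay: nitro does as well, with a 5.6-fold higher number from compound 2 to compound 3 (0.75 log units; beyond the scatter). Nitro in place of bromo also moves the number down, with an at least 2.9-fold lower number from compound 1 to compound 3 (0.46 log units; beyond the scatter), so the three groups at this position fall in one order, from lowest number to highest: diethylamino, nitro, bromo. The size of the step from bromo to nitro stays open-ended because the bromo compound stands at a limit and not at a number: the limit of > 10000 nM in this assay, at which 1 of the 3 values shown sits.

The compounds shown leave open where a dimethylamino group, a methoxy group or a carboxylic acid at the same place would fall in that order. They also leave open whether the order holds once the shared core is changed elsewhere.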